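From Hydroxymethyl to Ethylcarbamoyl on a Shared Core

The source may report more compounds than this note shows. Statements on the series, on what has been measured and on what is new or still open speak of the compounds shown alone.

Compound 1 `COc1ccc2c(c1)OC(c1cc(OC)c(OC)c(OC)c1)C(CO)=C2` carries a hydroxymethyl group on a double-bonded ring carbon of its core. In a functional assay for inhibition of nuclear factor NF-kappa-B complex (Homo sapiens) (on this read-out lower numbers stand for stronger inhibition and higher numbers for weaker inhibition), compound 1 gives only a limit of the assay, > 50000 nM. Compound 2 `COc1ccc2c(c1)OC(c1cc(OC)c(OC)c(OC)c1)C(C(=O)OC(C)(C)C)=C2` bears a tert-butoxycarbonyl group at that carbon, and in this assay compound 2 gives 14100 nM. That change is an at least 3.5-fold lower number from compound 1 to compound 2 (0.54 log units; beyond the scatter). Compound 3 `COc1ccc2c(c1)OC(c1cc(OC)c(OC)c(OC)c1)C(C(=O)N(C)C)=C2` carries a dimethylcarbamoyl group there, and in this assay compound 3 again reaches only a limit of the assay, > 50000 nM. From compound 1 the step is a step that the two limits leave unreadable from compound 1 to compound 3, while the step from the ester to the amide is an at least 3.5-fold higher number from compound 2 to compound 3 (0.54 log units; beyond the scatter). The picture is dominated by the limit of > 50000 nM in this assay, at which 2 of the 3 values shown sit.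

Compound 4 `CCNC(=O)C1=Cc2ccc(OC)cc2OC1c1cc(OC)c(OC)c(OC)c1` is not yet measured. Relative to compound 1 the change is ethylcarbamoyl in place of hydroxymethyl on a double-bonded ring carbon. Among the compounds with values here, the closest measured step is the one to compound 3, in which a dimethylcarbamoyl group left the number at the limit; the ester of compound 2 is the only group that moved it. An ethylcarbamoyl group is an amide like that of compound 3, so no step beyond the scatter is expected in this assay, and a limit is the likelier outcome. Compound 4 is expected to give about 50000 nM, between 15000 nM and 200000 nM. The expected step is a number no higher from compound 1 to compound 4 (the limit leaves the size open).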

Compound 4, half-maximal inhibitory concentration: > 50000 nM
Compound 4: a limit, no number (the forecaster's own chance of this, stated with the estimate: 65%); the middle value sits exactly at the limit.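

Compound 4 stands as a limit of the assay, > 50000 nM. Setting ethylamino in place of tert-butoxy on the carbonyl carbon gives an at least 3.5-fold higher number from compound 2 to compound 4 (0.54 log units; beyond the scatter), so a second amide at this double-bonded ring carbon, now with ethylamino rather than dimethylamino, also fails to keep the measurable value of the ester in this assay. The steps from compound 1 and from compound 3 to compound 4 join two limits and cannot be read, and the ester of compound 2 remains the only group at this carbon with a number, the rest of the series resting on one limit: the limit of > 50000 nM in this assay, at which 3 of the 4 values shown sit.

What the compounds shown leave open is whether the number of compound 2 belongs to the ester link or to its tert-butyl group, a question that a methyl ester or a carboxylic acid at this carbon would address. They also leave open how hydroxymethyl, dimethylcarbamoyl and ethylcarbamoyl rank against one another, as all three stand at a limit, and whether an amine on a longer chain there would give a number at all.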